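A Shorter Aromatic Group Replaces a Long Chain

The compounds below may be only part of what the source reports. "The series", "measured", "known", "first", "only" and "open" are said of these compounds alone.

Measured in an ADME assay on AGS cells (Homo sapiens) for cytotoxicity, read by neutral red uptake, with a stated time of 24 h; on this read-out higher numbers stand for weaker inhibition and lower numbers for stronger inhibition
- Compound 1 `CCCC(=O)Oc1c(C(C)C)cc2c3c1OC(=O)[C@@]31CCCC(C)(C)[C@@H]1CC2` gives 99500 nM
- Compound 2 `CCCCCCCCCCCC(=O)Oc1c(C(C)C)cc2c3c1OC(=O)[C@@]31CCCC(C)(C)[C@@H]1CC2` gives 413000 nM

Compound 2 has the higher of these two numbers, so it is the weaker inhibitor of the pair. Compound 3 `CC(C)c1cc2c3c(c1OC(=O)c1cccnc1)OC(=O)[C@@]31CCCC(C)(C)[C@@H]1CC2` keeps the shared core but has pyridin-3-yl in place of undecyl on a carbonyl carbon. Among the compounds with values here, only one measured step bears on this change. Lengthening the chain gives a 4.2-fold higher number from compound 1 to compound 2 (0.62 log units; beyond the scatter), a modest step beyond the scatter. Compound 3 gives up the long chain, so the expectation is that its number falls back towards that of compound 1 at 99500 nM. Within the data shown here, this is only a rough guide, since no measured compound carries an aromatic ring at this carbonyl carbon, and the true value could land on either side of compound 1. The expected change is a 3.8-fold lower number from compound 2 to compound 3 (0.57 log units; beyond the scatter), a modest drop. Compound 3 is therefore estimated at 110000 nM, with an expected range from 40000 nM to 300000 nM.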

Compound 3, half-maximal inhibitory concentration: 280000 nM
Estimate against measurement, compound 3: 2.5-fold (0.41 log units) below; the measured number falls inside the stated range.
By their numbers in this assay, from the lowest: compound 1; then compounds 3 and 2 (each within the scatter of the next).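

In this assay, pyridin-3-yl in place of undecyl on this carbonyl carbon gives a 1.5-fold lower number from compound 2 to compound 3 (0.17 log units; within the scatter) and so cannot be told apart from the long chain, even though the incoming group swaps an open chain for a six-membered aromatic ring carrying a hydrogen-bond acceptor. Set against the short propyl group, the same aromatic ring gives a 2.8-fold higher number from compound 1 to compound 3 (0.45 log units; beyond the scatter) and this step lies beyond the scatter, so among these three esters a number higher than the propyl value does not require a long chain. The earlier pair showed a higher number with the longer chain. A higher number than the propyl value is now seen with a very different group as well. No measurement here explains why these groups behave as they do.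

On these data alone, it remains open whether a plain phenyl ring, which lacks the ring nitrogen of pyridin-3-yl, would read the same way at this carbonyl carbon. Also open, as far as these compounds go, is how a chain of middle length such as hexyl, or a shorter one such as methyl, would compare with propyl and undecyl.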